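Adding a chloro group to compound 3

The compounds below may be only part of what the source reports. "The series", "measured", "known", "first", "only" and "open" are said of these compounds alone.

In a functional assay on HSC-4 cells (Homo sapiens) for cytotoxicity, with a stated time of 24 h (a lower number here means that less compound is tolerated, a higher number that more compound is tolerated), compound 1 (`O=C1/C(=C/c2ccc(Cl)cc2)CCC/C1=C\c1ccccc1[N+](=O)[O-]`) gives 6100 nM and compound 2 (`Cc1ccc(/C=C2\CCC/C(=C\c3ccccc3[N+](=O)[O-])C2=O)cc1`) gives 40000 nM as its value. Compound 3 (`O=C1/C(=C/c2ccccc2)CCC/C1=C\c1ccc([N+](=O)[O-])cc1`) stands at 9200 nM in the same read-out, within the scatter of compound 1 and clearly beneath compound 2. Compound 4 (`O=C1/C(=C/c2ccc(Cl)cc2)CCC/C1=C\c1ccc([N+](=O)[O-])cc1`) differs from compound 3 by chloro in place of hydrogen on an aromatic carbon. Among the compounds with values here, no measured step makes this change directly. The closest evidence is a 6.6-fold higher number from compound 1 to compound 2 (0.82 log units; beyond the scatter) for methyl in place of chloro, a modest step beyond the scatter that leaves the chloro compound with the lower number. Only a slight lowering, no step beyond the scatter, is expected in this assay with a 1.4-fold lower number from compound 3 to compound 4 (0.15 log units; within the scatter) as the estimated step. For compound 4 the estimate is 6500 nM with an expected range of 2800 nM to 15000 nM overall.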

Compound 4, half-maximal cytotoxic concentration: 2700 nM
Estimate against measurement, compound 4: 2.4-fold (0.38 log units) above; measured number outside the range, below it.
By their numbers in this assay, from the lowest: compound 4; then compounds 1 and 3 (each within the scatter of the next); then compound 2.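

In this assay the change from phenyl to 4-chlorophenyl now has a direct measurement, a 3.4-fold lower number from compound 3 to compound 4 (0.53 log units; beyond the scatter), a modest step beyond the scatter. Chloro on this aromatic carbon, para to a large group, thus gives a lower number than hydrogen, whereas the earlier compounds only set chloro against methyl. Nothing available explains this step.

The chloro effect rests on this single pair of compounds. On these data alone, whether fluoro, bromo or a methoxy group in the same place would give a similar number remains open.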